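This account rests on a few compounds, and the source may have more. Where it says the series, first, only, none or still open, it means among the compounds named here.

Of the compounds shown here, two have so far been measured in an assay on isolated protein for inhibition of Amine oxidase [flavin-containing] B (Homo sapiens), read by fluorescence, with stated times of 15 min and 20 min; a higher number here means a weaker inhibitor, a lower number a stronger inhibitor. Compound 1 `CC(C)(C)c1cc(C(=O)NC2CCN(Cc3ccccc3)CC2)cc(C(C)(C)C)c1O` gives the higher of the two numbers: in this assay compound 1 gives 85100 nM. Compound 2 `CC(C)(C)c1cc(/C=C/C(=O)NCCC2CCN(Cc3ccccc3)CC2)cc(C(C)(C)C)c1O` stands lowest of the two, and in this assay compound 2 gives 8500 nM, a gap to compound 1 that lies well beyond the scatter of repeated measurements. Compound 2 is therefore the stronger inhibitor of the pair as matters stand.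

Compound 3 `COc1ccc(CN2CCC(CCNC(=O)/C=C/c3cc(C(C)(C)C)c(O)c(C(C)(C)C)c3)CC2)cc1` keeps the whole of compound 2 and changes a single place: methoxy in place of hydrogen on an aromatic carbon. Within the data shown here, no measured pair shows what this particular change does in this assay, so the expectation rests on compound 2 as the only starting point and on the small size of the added group. The step expected from compound 2 to compound 3 is a 1.1-fold lower number from compound 2 to compound 3 (0.03 log units; within the scatter), which is not expected to reach beyond the usual scatter in either direction. Compound 3 is accordingly estimated to give about 8000 nM in this assay, with a likely range from 3000 nM to 25000 nM.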

Compound 3, half-maximal inhibitory concentration: 6700 nM
Compound 3: middle estimate off by 1.2-fold (0.08 log units), on the high side, within the range that was stated.
By their numbers in this assay, from the lowest: compounds 3 and 2 (each within the scatter of the next); then compound 1.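

In this assay, methoxy in place of hydrogen on the aromatic carbon para to a large group, which turns the benzyl into 4-methoxybenzyl, gives a 1.3-fold lower number from compound 2 to compound 3 (0.10 log units; within the scatter). Among these compounds, this is the first reading at this position, and it shows that compound 2 and compound 3 cannot be told apart in this measurement. A substituent of 2 heavy atoms, one carbon and one oxygen, can therefore stand at this place on the ring while the number stays within ordinary measurement scatter, so this change by itself neither clearly helps nor clearly harms inhibition. No independent measurement is available to explain this result.

As far as these compounds go, one group at one place is a narrow test, so it remains open whether fluorine, a hydroxyl group, a dimethylamino group or a carboxylic acid on the same ring carbon would shift the number beyond the scatter. Also open, from the compounds shown here alone, are whether a longer chain such as ethoxy or butoxy would be accommodated there, and whether methoxy on a different carbon of this ring would give a similar result.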